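Two Weakly Cytotoxic Guanidine Analogues and a Dichlorobenzyl Ether

The source may report more compounds than this note shows. Statements on the series, on what has been measured and on what is new or still open speak of the compounds shown alone.

Compound 1: `CN(C)C1=NC(c2ccc(/C=C/C(=O)c3ccc(Cl)cc3Cl)cc2)N=C(N)N1`, 45100 nM
Compound 2: `CN(C)C1=NC(c2ccc3cc(OCC(=O)c4ccc(Br)cc4)ccc3c2)N=C(N)N1`, 58700 nM

In an ADME assay on L02 cells (Homo sapiens) for inhibition, read by MTT assay, with a stated time of 24 h (on this read-out lower numbers stand for stronger inhibition and higher numbers for weaker inhibition), compound 1 gives 45100 nM and compound 2 gives 58700 nM. Of the two numbers, that of compound 2 is the upper one, yet compound 1 sits so close that the gap is within the usual scatter, and the two cannot be told apart. Compound 3 (`CN(C)C1=NC(c2ccc3cc(OCc4ccc(Cl)cc4Cl)ccc3c2)N=C(N)N1`) is not yet measured. It differs from compound 2 by 2,4-dichlorophenyl in place of (4-bromophenyl)carbonyl on a saturated chain carbon bound to an oxygen on an aromatic ring. Among the compounds with values here, no measured pair shows what such a change does, so in this assay no step beyond the scatter is expected in either direction. Compound 3 is therefore estimated at 50000 nM, between 22000 nM and 110000 nM, a step of a 1.2-fold lower number from compound 2 to compound 3 (0.07 log units; within the scatter).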

Compound 3, half-maximal inhibitory concentration: 58900 nM
Estimate against measurement, compound 3: 1.2-fold (0.07 log units) below; low and high end bracket the measured number.
By their numbers in this assay, from the lowest: compounds 1, 2 and 3 (each within the scatter of the next).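

In this assay, within the data shown here, the exchange of ((4-bromophenyl)carbonyl)methyl for 2,4-dichlorobenzyl on the oxygen on an aromatic ring gives the first step that can be read (a 1.0-fold higher number from compound 2 to compound 3 (0.00 log units; within the scatter)). At this place, then, the carbonyl and the bromine can both leave, and two chlorines enter, with no step beyond the scatter. No evidence at hand bears on this result. As far as these compounds go, whether an amine or a carboxylic acid at this place would move the number beyond the scatter stays open. So does the effect of a longer chain, and of either exchange made alone.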